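Urea series: nitrile for chloride on the pyridine core

This account rests on a few compounds, and the source may have more. Where it says the series, first, only, none or still open, it means among the compounds named here.

Compound 1 `CCOc1nc(Cl)cc(NC(=O)NCc2cc(C)c(-c3cn(C)nc3C(F)(F)F)nn2)c1C` is the reference point. In a functional assay on CHO cells for agonist activity at sphingosine 1-phosphate receptor 2 (Homo sapiens), read by fluorescence and calcium flux, with a stated time of 3 min (a higher number here means a weaker inhibitor, a lower number a stronger inhibitor), compound 1 gives 4800 nM. Compound 2 `CCOc1nc(C#N)cc(NC(=O)NCc2cc(C)c(-c3cn(C)nc3C(F)(F)F)nn2)c1C` differs from it by cyano in place of chloro on an aromatic carbon, and the step is a 1.1-fold higher number from compound 1 to compound 2 (0.06 log units; within the scatter). Compound 3 `CCOc1nc(C)cc(NC(=O)NCc2cc(C)c(-c3cn(C)nc3C(F)(F)F)nn2)c1Cl` carries a rearranged core, (3-chloro-2-ethoxy-6-methylpyridin-4-yl in place of 6-chloro-2-ethoxy-3-methylpyridin-4-yl on an amide-type nitrogen), and shows a 1.0-fold higher number from compound 1 to compound 3 (0.01 log units; within the scatter); in this assay compound 3 gives 4900 nM, while compound 2 gives 5500 nM. All three values sit together within the scatter, so no order among them can be read.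

Compound 4 `CCOc1nc(C)cc(NC(=O)NCc2cc(C)c(-c3cn(C)nc3C(F)(F)F)nn2)c1C#N` is not yet measured. It differs from compound 3 by cyano in place of chloro on an aromatic carbon. For the measured compounds named here, this is the same kind of change as the one from compound 1 to compound 2, but not the same: in that earlier pair the carbon is next to the ring nitrogen, meta to a large group and meta to an ethoxy group, whereas in compound 4 the carbon is ortho to a large group, ortho to an ethoxy group and two atoms from the ring nitrogen; both are para to a methyl group.

The expected step for compound 4 is a 1.1-fold higher number from compound 3 to compound 4 (0.05 log units; within the scatter), which rests on the near-flat earlier step a 1.1-fold higher number from compound 1 to compound 2 (0.06 log units; within the scatter) and on the fact that all three measured values lie within the scatter of one another. Compound 4 is therefore estimated at 5500 nM in this assay, with a plausible range from 2500 nM to 12000 nM.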

Compound 4, half-maximal inhibitory concentration: < 2300 nM
Compound 4 ended at the assay's limit; the forecaster's own chance of this, stated with the estimate: 15%; middle value at least 2.3-fold (0.37 log units) from the limit.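

The value for compound 4 is a limit of the assay and not a number: the limit of < 2300 nM in this assay, at which 1 of the 4 values shown sits. On the core of compound 3, with the carbon ortho to a large group and ortho to an ethoxy group, cyano in place of chloro gives an at least 2.1-fold lower number from compound 3 to compound 4 (0.32 log units; beyond the scatter), so the change is a step beyond the scatter on this core, though its full size cannot be read. This does not establish that the change behaves differently from one core to the other, nor does it show that it carries over unchanged, and one pair per core cannot separate the core itself from where the carbon sits on it: the same change on two cores in this assay, a 1.1-fold higher number (0.06 log units; within the scatter) from compound 1 to compound 2 and an at least 2.1-fold lower number (0.32 log units; beyond the scatter) from compound 3 to compound 4; the limit leaves it open whether they differ.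

Chloro and cyano are the only groups compared at this carbon, so it stays open whether the lower number in this assay is particular to cyano or would also appear with a fluoro, a methoxy or an amine there. As far as these compounds go, it also stays open whether the step on the core of compound 3 would hold if the ethoxy group gave way to a longer chain, and a measured number for compound 4 would be needed to size the step at all.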